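Notes on dropping one hydroxy from compound 3

The source may report more compounds than this note shows. Statements on the series, on what has been measured and on what is new or still open speak of the compounds shown alone.

Measured compounds:
- compound 1, `Cc1ccc(/C=C2\CCC/C(=C\c3ccccc3)C2=O)cc1`: "not determined" (no result reported)
- compound 2, `O=C1/C(=C/c2ccccc2)CCC/C1=C\c1cccc(Br)c1`: "not determined" (no result reported)
- compound 3, `O=C1/C(=C/c2ccccc2)CCC/C1=C\c1ccc(O)c(O)c1`: 20300 nM

In an assay on isolated protein for inhibition of Alpha glucosidase (Homo sapiens), with stated times of 5 min and 15 min (on this read-out lower numbers stand for stronger inhibition and higher numbers for weaker inhibition), compound 3 gives 20300 nM. Going by the values given here, compound 3 is the only member of the series with a number attached; compound 1 gives "not determined" (no result reported) and compound 2 gives "not determined" (no result reported), so nothing can be said of how the methyl or the bromo analogues compare, and no pattern across the series can be claimed. Compound 3 therefore stands alone as the single anchor for any expectation.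

Compound 4, `O=C1/C(=C/c2ccccc2)CCC/C1=C\c1cccc(O)c1`, is the next compound to be measured. It differs from compound 3 in one place: hydrogen in place of hydroxy on an aromatic carbon

Among the compounds with values here, with no measured step available, the size of the change can only be guessed from the structural change itself. Within the data shown here, the expectation is that the step of a 2.2-fold higher number from compound 3 to compound 4 (0.35 log units; beyond the scatter) goes toward weaker inhibition, by an amount somewhat beyond the usual scatter, because the only anchor is compound 3 at 20300 nM and one of its two hydroxy groups is removed. Compound 4 is estimated at 45000 nM, with a range from 15000 nM to 150000 nM.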

Compound 4, half-maximal inhibitory concentration: 28400 nM
Estimate against measurement, compound 4: 1.6-fold (0.20 log units) above, within the range that was stated.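

In this assay, going by these compounds alone, hydrogen in place of hydroxy gives a 1.4-fold higher number from compound 3 to compound 4 (0.15 log units; within the scatter), the first step that can be read, and it stays within the usual scatter. On the data shown, this hydroxy, ortho to a hydroxy group and para to a large group, can leave without a change that can be told from repeat measurement, so compound 3 and compound 4 cannot be ranked against each other. This is one step at one position and supports no wider claim about hydroxy groups on this ring, and no measured information explains the result.

From the compounds shown here alone, whether the hydroxy that remains in compound 4 matters stays open, since compound 1 and compound 2 carry no number in this assay and so give no comparison. Within the data shown here, also open is what an amine or a carboxylic acid would give at the position tested here, since a hydrogen in place of hydroxy is the only change at this position that can be read so far.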